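Replacing the pyridinyloxy group in compound 3 with methoxymethyl

This account rests on a few compounds, and the source may have more. Where it says the series, first, only, none or still open, it means among the compounds named here.

Compound 3 `Fc1cccc(F)c1Cc1cnc(Nc2ccc(Oc3ccncc3)cc2)o1` is the reference point. In an ADME assay on MT2 cells (Homo sapiens) for cytotoxicity, read by MTT assay (a higher number here means that more compound is tolerated, a lower number that less compound is tolerated), compound 3 gives 21000 nM. Within the data shown here, its closest neighbour is compound 2 `Fc1cccc(F)c1Cc1cnc(Nc2ccc(Oc3ccncc3)c(Cl)c2)o1`, which in this assay gives 21000 nM; the only step measured, no change at the digits printed from compound 2 to compound 3 (within the scatter), is the change described as hydrogen in place of chloro on an aromatic carbon. Compound 1 `Clc1cccc(Cl)c1Cc1nnc(Nc2ccc(COCc3ccccn3)cc2)o1` is reported in this assay only as a limit, > 100000 nM, which is the limit of > 100000 nM in this assay, at which 1 of the 3 values shown sits. Compound 4 `COCc1ccc(Nc2ncc(Cc3c(F)cccc3F)o2)cc1` has not yet been measured; it differs from compound 3 by methoxymethyl in place of (pyridin-4-yl)oxy on an aromatic carbon. Among the measured compounds shown here, no measured step covers a change of this kind: the one step on record, from compound 2 to compound 3, left the read-out unchanged and concerns a different part of the molecule, so it gives little guidance. The author therefore expects compound 4 to sit near compound 3, with the change a 1.4-fold higher number from compound 3 to compound 4 (0.15 log units; within the scatter) not clearly beyond the scatter, and estimates for compound 4 a value of 30000 nM in this assay, between 10000 nM and 100000 nM.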

Compound 4, half-maximal cytotoxic concentration: 32000 nM
Estimate against measurement, compound 4: 1.1-fold (0.03 log units) below, within the range that was stated.
By their numbers in this assay, from the lowest: compounds 2, 3 and 4 (each within the scatter of the next). At a limit, above all of these: compound 1.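

Among these compounds, this is the first measured change at this position, on an aromatic carbon para to a large group, since the earlier step concerned the chloro substituent. In this assay, methoxymethyl in place of (pyridin-4-yl)oxy gives a 1.5-fold higher number from compound 3 to compound 4 (0.18 log units; within the scatter). The ring of the (pyridin-4-yl)oxy group can therefore give way to a group with no ring while the read-out stays within the scatter, though nothing measured here gives a reason for this.

Going by these compounds, whether an amine, a carboxylic acid or a chain longer than methoxymethyl at this position would also leave the read-out in place remains open. Compound 1 gives only a limit, > 100000 nM, and it differs from compound 4 in more than one place, so it cannot settle that question.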